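The compounds below may be only part of what the source reports. "The series", "measured", "known", "first", "only" and "open" are said of these compounds alone.

Compound 1 `O=C(O)c1ccc(-c2nc3cccnc3n2C2CCCC2)cc1` in a functional assay on MDA-MB-231 cells (Homo sapiens) for cytotoxicity, read by MTT assay, with a stated time of 24 h (a higher number here means a weaker inhibitor, a lower number a stronger inhibitor), gives 600 nM, the highest of the two numbers recorded here. Compound 2 `CN(C)c1ncc(-c2nc3cccnc3n2C2CCCC2)cn1` gives 45 nM, a gap beyond the usual scatter. Compound 3 `c1cnc2c(c1)nc(-c1ccc(-c3nnco3)cc1)n2C1CCCC1` differs from compound 1 in one place: 1,3,4-oxadiazol-2-yl in place of carboxy on an aromatic carbon. Going by the values given here, no measured pair shows this same change, so its size is not known from the data. A modest shift toward a lower number is nonetheless expected, a 2.0-fold lower number from compound 1 to compound 3 (0.30 log units; within the scatter), though the outcome could also stay within the scatter. On that basis compound 3 is estimated to give 300 nM in this assay, with a range from 100 nM to 900 nM.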

Compound 3, half-maximal inhibitory concentration: 87 nM
Estimate against measurement, compound 3: 3.4-fold (0.54 log units) above; measured number below the stated range.
By their numbers in this assay, from the lowest: compounds 2 and 3 (each within the scatter of the next); then compound 1.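

In this assay, putting 1,3,4-oxadiazol-2-yl in place of carboxy on the aromatic carbon para to a large group gives a 6.9-fold lower number from compound 1 to compound 3 (0.84 log units; beyond the scatter) with the rest of compound 1 unchanged. Going by these compounds alone, this is the first one-place step here, and it shows that the number at this position responds to the group placed there and that carboxy, with its hydrogen-bond donor, is not required. No measurement offered here explains this step. On these data alone, whether an amide, a nitrile or a methyl ester at this position would give a similar number remains open.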